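This account rests on a few compounds, and the source may have more. Where it says the series, first, only, none or still open, it means among the compounds named here.

Measured so far in a functional assay on NCI-H1993 cells (Homo sapiens) for inhibition, read by CCK-8 assay, with a stated time of 72 h; a lower number here means a stronger inhibitor, a higher number a weaker inhibitor:
- compound 1 `CCC(c1ccc2ncccc2c1F)n1cnc2ncc(-c3cn[nH]c3)nc21`: "not determined" (no result reported)
- compound 2 `CCC(c1cc2cccnc2cc1F)n1cnc2ncc(-c3ccccc3)nc21`: "not determined" (no result reported)
- compound 3 `c1cnc2ccc(Cn3cnc4ncc(-c5cn[nH]c5)nc43)cc2c1`: 2890 nM

Compound 1 has no single number in this assay, and compound 2 has none either. The only figure in the series is therefore that of compound 3, at 2890 nM.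

Next to be measured is compound 4 `CCC(c1ccc2ncccc2c1F)n1cnc2ncc(-c3ccc(C(N)=O)c(F)c3)nc21`, which keeps the core of compound 1. The structural change is 4-carbamoyl-3-fluorophenyl in place of 1H-pyrazol-4-yl on an aromatic carbon.

Among the measured compounds shown here, no measured pair shows this exchange, and without a starting number its step cannot be sized from compound 1. The expectation in this assay is therefore set against compound 3 alone, which gives 2890 nM: a clear move towards stronger inhibition is expected, on thin evidence and with a wide margin.

The estimate for compound 4 is 150 nM, with an expected range from 10 nM to 2000 nM.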

Compound 4, half-maximal inhibitory concentration: 665 nM
For compound 4 the middle estimate is 4.4-fold (0.65 log units) below the measured one; measured number inside the range.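

In this assay, among the compounds shown here, compound 4 gives 665 nM, but compound 1 has no single number, so no step between compound 1 and compound 4 can be read. The compounds shown leave open what exchanging 1H-pyrazol-4-yl for 4-carbamoyl-3-fluorophenyl alone does to inhibition. No evidence bears on this result.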